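A Chloro Group Added to Compound 1

A few compounds are considered here, and "the series" means these few. Any claim that something is new, unique, unknown or untested is made for them only; others in the source may bear on it.

Compound 1 `O=C(Nc1ccccc1)c1cc(Br)ccc1O` stands at a limit in an assay for inhibition of HSP60/HSP10 (Homo sapiens), with a stated time of 60 min; a lower number here means a stronger inhibitor, a higher number a weaker inhibitor: compound 1 gives > 100000 nM, which is a limit of the assay and not a number. Compound 2 `O=C(Nc1ccccc1)c1cccc(Br)c1` likewise gives only a limit, > 100000 nM. Compound 3 `O=C(Nc1ccccc1)c1cc(Br)cc(Br)c1O` gives 63000 nM. The step that the two limits leave unreadable from compound 1 to compound 2 removes the hydroxy from the core, and the step of an at least 1.5-fold lower number from compound 1 to compound 3 (0.20 log units; that floor lies within the scatter) adds a second bromo to the core. Two of the three values sit at the limit of > 100000 nM in this assay, at which 2 of the 3 values shown sit. Within the data shown here, compound 4 `O=C(Nc1cccc(Cl)c1)c1cc(Br)ccc1O` differs from compound 1 by chloro in place of hydrogen on an aromatic carbon, a change that no measured step touches. With compound 1 at its limit, compound 4 is expected to remain weak, a step of a number no higher from compound 1 to compound 4 (the limit leaves the size open). The estimate for compound 4 is 100000 nM, within 30000 nM to 300000 nM.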

Compound 4, half-maximal inhibitory concentration: > 100000 nM
Compound 4 ended at the assay's limit (the forecaster's own chance of this, stated with the estimate: 65%); the middle value lies on the limit itself.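

No new step can be read between compound 1 and compound 4, because both stand at a limit of this assay and not at a number: the limit of > 100000 nM in this assay, at which 3 of the 4 values shown sit. The compounds shown leave open what size of change, if any, the chloro group brings.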